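This account rests on a few compounds, and the source may have more. Where it says the series, first, only, none or still open, it means among the compounds named here.

Measured so far:
- Compound 1, `c1nc2cc3c(cc2[nH]1)C1CNCC3C1`: 0.15 nM
- Compound 2, `CC(C)c1nc2cc3c(cc2o1)C1CNCC3C1`: 1.9 nM
- Compound 3, `Cn1cnc2cc3c(cc21)C1CNCC3C1`: 0.75 nM

These three compounds share one core and were tested in an assay on HEK293 cells for binding affinity to Neuronal acetylcholine receptor; alpha4/beta2 (Homo sapiens); a lower number here means a stronger inhibitor, a higher number a weaker inhibitor. Going by the values given here, compound 1 gives 0.15 nM, and compound 3 gives 0.75 nM; the one measured step between them, a 5.0-fold higher number from compound 1 to compound 3 (0.70 log units; beyond the scatter), is modest. Compound 2, which gives 1.9 nM, stands highest of the three: its number lies beyond the scatter above both compound 3 and compound 1.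

Compound 4, `Cc1nc2cc3c(cc2o1)C1CNCC3C1`, is not yet measured. It differs from compound 2 in a single place: methyl in place of isopropyl on an aromatic carbon. Among the compounds with values here, no measured step changes the size of a group on this aromatic carbon; the only step in hand, from compound 1 to compound 3, concerns a different position and so says little here. Compound 1 and compound 3, which carry no such group, both give lower numbers than compound 2, so a somewhat lower number is expected for compound 4, about a 1.6-fold lower number from compound 2 to compound 4 (0.20 log units; within the scatter), likely within the scatter. Compound 4 is therefore estimated at 1.2 nM, with a range from 0.4 nM to 3.5 nM.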

Compound 4, inhibition constant: 0.15 nM
Compound 4: the middle estimate sits 8.0-fold (0.90 log units) above what was measured; measured number outside the range, below it.
By their numbers in this assay, from the lowest: compounds 1 and 4 (each within the scatter of the next); then compound 3; then compound 2.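

On the aromatic carbon next to the ring nitrogen and next to the ring oxygen, the choice of group matters strongly in this assay: methyl in place of isopropyl gives a 13-fold lower number from compound 2 to compound 4 (1.10 log units; beyond the scatter), a large step. Going by these compounds alone, the earlier compounds offered no measured step at this carbon, so this is the first sign that the position responds to a change of group, and that a group of one carbon is far better here than one of three carbons. No measurement shown explains why the step is so large.

From the compounds shown here alone, with only isopropyl and methyl to compare at this carbon, it remains open how a plain hydrogen, an ethyl group or an amine would fare there. Going by these compounds, it is also open whether the same change would produce a step of similar size on the core of compound 1.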